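A few compounds are considered here, and "the series" means these few. Any claim that something is new, unique, unknown or untested is made for them only; others in the source may bear on it.

In a functional assay on HL-60 cells (Homo sapiens) for cytotoxicity, read by WST assay, with a stated time of 48 h (a lower number here means that less compound is needed, a higher number that more compound is needed for the effect), three compounds with a shared core have been measured. Compound 1 (`Oc1cccc(C[C@H]2COC[C@@H]2Cc2ccc(Cl)c(Cl)c2)c1`) gives 31000 nM, compound 2 (`COc1ccc(C[C@H]2COC[C@@H]2Cc2ccc(Cl)c(Cl)c2)cc1`) gives 39000 nM and compound 3 (`Fc1ccc(C[C@H]2COC[C@@H]2Cc2ccc(Cl)c(Cl)c2)cc1`) gives 43000 nM, so compound 2 stands within the usual scatter of both others.

Compound 4 (`COc1ccc(C[C@H]2COC[C@@H]2Cc2ccc(Cl)c(Cl)c2)cc1O`) is compound 2 with hydroxy in place of hydrogen on an aromatic carbon, ortho to a methoxy group: hydroxy in place of hydrogen on an aromatic carbon.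

Among the measured compounds shown here, two measured steps bear on this. Fluoro in place of methoxy on an aromatic carbon gave a 1.1-fold higher number from compound 2 to compound 3 (0.04 log units; within the scatter). For the measured compounds named here, the 4-fluorophenyl in place of 3-hydroxyphenyl gave a 1.4-fold higher number from compound 1 to compound 3 (0.14 log units; within the scatter), the only measured step that touches a hydroxy group. Going by the values given here, neither step adds a hydroxy group to a ring that keeps its methoxy group, so the data offer no direct precedent. Since both steps stay within the scatter, no clear shift is expected in this assay.

The expected change is small, an estimated 1.2-fold lower number from compound 2 to compound 4 (0.09 log units; within the scatter). For compound 4 the estimated value is 32000 nM, with an expected range from 15000 nM to 65000 nM.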

Compound 4, half-maximal effective concentration: 33000 nM
For compound 4 the middle estimate is 1.0-fold (0.01 log units) below the measured one; the measured number falls inside the stated range.
By their numbers in this assay, from the lowest: compounds 1, 4, 2 and 3 (each within the scatter of the next).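

Hydroxy on the aromatic carbon ortho to a methoxy group is tolerated in this assay, with the step staying within the scatter (a 1.2-fold lower number from compound 2 to compound 4 (0.07 log units; within the scatter)). The same ring can also be reached from the other side, by methoxy in place of hydrogen on a ring that already carries hydroxy, and this step also stays within the scatter (a 1.1-fold higher number from compound 1 to compound 4 (0.03 log units; within the scatter)). The earlier compounds shown here each carried a single group on this ring, whereas compound 4 shows that hydroxy and methoxy together give a number within the scatter of both single-group compounds.

From the compounds shown here alone, whether an amine or a carboxylic acid at this position, or a longer chain such as ethoxy in place of methoxy, would give a step beyond the scatter remains open. Nothing measured here speaks to what lies behind these small steps.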